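A few compounds are considered here, and "the series" means these few. Any claim that something is new, unique, unknown or untested is made for them only; others in the source may bear on it.

In an ADME assay on HUVEC cells (Homo sapiens) for cytotoxicity, read by MTT assay, with a stated time of 24 h (a lower number here means that less compound is tolerated, a higher number that more compound is tolerated), compound 1 `Brc1cccc(/C=C/c2nnc(-c3ccc4c(c3)OCCO4)o2)c1` gives 322000 nM, compound 2 `Cc1ccc(/C=C/c2nnc(-c3ccc4c(c3)OCCO4)o2)cc1` gives 265000 nM and compound 3 `Fc1ccc(/C=C/c2nnc(-c3ccc4c(c3)OCCO4)o2)cc1` gives 325000 nM, so compound 3 stands level with both others within the scatter. Compound 4 `Fc1ccccc1/C=C/c1nnc(-c2ccc3c(c2)OCCO3)o1` has 2-fluorophenyl in place of 4-fluorophenyl on a double-bonded chain carbon bound to a double-bonded chain carbon. Going by the values given here, no measured compound carries 2-fluorophenyl, but three steps change the phenyl group at this place: a 1.2-fold lower number from compound 1 to compound 2 (0.08 log units; within the scatter), a 1.0-fold higher number from compound 1 to compound 3 (0.00 log units; within the scatter) and a 1.2-fold higher number from compound 2 to compound 3 (0.09 log units; within the scatter). All three are small. The expected step, a 1.1-fold lower number from compound 3 to compound 4 (0.03 log units; within the scatter), therefore stays within the scatter, with no direction favoured. For compound 4 the estimated value is 300000 nM, with an expected range from 170000 nM to 520000 nM.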

Compound 4, half-maximal cytotoxic concentration: 402000 nM
The estimate for compound 4 lay 1.3-fold (0.13 log units) below the measured number; the measured number falls inside the stated range.
By their numbers in this assay, from the lowest: compounds 2, 1, 3 and 4 (each within the scatter of the next).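

In this assay the change of 2-fluorophenyl in place of 4-fluorophenyl, which keeps the same atoms and joins them differently, gives a 1.2-fold higher number from compound 3 to compound 4 (0.09 log units; within the scatter) and so stays within the scatter. The steps from the other phenyl groups, a 1.5-fold higher number from compound 2 to compound 4 (0.18 log units; within the scatter) and a 1.2-fold higher number from compound 1 to compound 4 (0.10 log units; within the scatter), are also within the scatter, so all four phenyl groups at this place stand level in this assay. Nothing measured here explains these numbers. From the compounds shown here alone, whether an amine, a carboxylic acid or a longer chain at this place would move the number beyond the scatter stays open.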